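Aryl swap on the ring nitrogen: compound 2 to compound 3

The source may hold more compounds than are shown below. What is called first, only, known or untested is meant among the compounds shown, and "the series" means these compounds.

Measured in a functional assay on A549 cells (Homo sapiens) for cytotoxicity, read by MTT assay, with a stated time of 72 h; on this read-out lower numbers stand for stronger inhibition and higher numbers for weaker inhibition:
Compound 1 `Cn1ccc2c(Oc3ccc(NC(=O)c4cc5cccnc5n(-c5ccc(Cl)cc5)c4=O)cc3)ncnc21`: 75500 nM
Compound 2 `COc1ccc(-n2c(=O)c(C(=O)Nc3ccc(Oc4ncnc5c4ccn5C)cc3)cc3cccnc32)cc1`: 83200 nM

On these numbers compound 2 stands level with compound 1, since the two values lie within the scatter of each other and neither ranks ahead. The next compound to consider is compound 3 `Cn1ccc2c(Oc3ccc(NC(=O)c4cc5cccnc5n(-c5ccc(C(F)(F)F)c(Cl)c5)c4=O)cc3)ncnc21`, which differs from compound 2 in one place: 3-chloro-4-(trifluoromethyl)phenyl in place of 4-methoxyphenyl on an aromatic nitrogen. In words, 3-chloro-4-(trifluoromethyl)phenyl stands in place of 4-methoxyphenyl on an aromatic nitrogen.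

Going by the values given here, only one measured step bears on this change: a 1.1-fold higher number from compound 1 to compound 2 (0.04 log units; within the scatter), with methoxy in place of chloro on an aromatic carbon. Among the compounds with values here, no measured compound carries trifluoromethyl, so this single small step is thin support and the range has to stay wide. No step beyond the scatter is therefore expected in this assay, in either direction. The expected change is a 1.2-fold lower number from compound 2 to compound 3 (0.08 log units; within the scatter). For compound 3 the estimated value is 70000 nM, with an expected range of 25000 nM to 130000 nM.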

Compound 3, half-maximal inhibitory concentration: "not active" (no number reported)
Nothing numeric was reported for compound 3; there is nothing to compare the estimate with.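

Going by these compounds alone, compound 3 is reported as "not active" with no number in this assay, so no step from compound 2 to compound 3 can be read. No measured evidence bears on this result. The compounds shown leave open how far 3-chloro-4-(trifluoromethyl)phenyl in place of 4-methoxyphenyl on the aromatic nitrogen shifts the read-out.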